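A Methoxymethyl Ester in Place of the Amide

The source may hold more compounds than are shown below. What is called first, only, known or untested is meant among the compounds shown, and "the series" means these compounds.

Compound 2 `CC(C)=CCC/C(C)=C/CC/C(C)=C/CSc1ccccc1C(N)=O` gives 10000 nM in a functional assay on U-87MG ATCC cells (Homo sapiens) for cytotoxicity, with a stated time of 7 days (a lower number here means a stronger inhibitor, a higher number a weaker inhibitor), the lowest of the two numbers recorded there. Compound 1 `CC(C)=CCC/C(C)=C/CC/C(C)=C/CSc1ccccc1C(=O)OCc1ccccc1` carries a benzyloxy group where compound 2 carries amino. In this assay compound 1 gives 30000 nM; the measured step was a 3.0-fold lower number from compound 1 to compound 2 (0.48 log units; beyond the scatter).

Compound 3 `COCOC(=O)c1ccccc1SC/C=C(\C)CC/C=C(\C)CCC=C(C)C` differs from compound 2 in one place: methoxymethoxy in place of amino on a carbonyl carbon. Among the measured compounds shown here, only one measured step bears on this change, the move from the benzyloxy ester to the amide, a 3.0-fold lower number from compound 1 to compound 2 (0.48 log units; beyond the scatter), which ran toward a lower number when the amide entered. Compound 3 goes back to an ester, so the reverse direction is expected: a modestly higher number in this assay. For the measured compounds named here, the methoxymethoxy group is not the benzyloxy group of compound 1, and no measured pair shows how that particular difference plays out, so the range is kept wide. Compound 3 is therefore expected to give about 20000 nM in this assay, within 7000 nM to 60000 nM. The expected step is a 2.0-fold higher number from compound 2 to compound 3 (0.30 log units; within the scatter).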

Compound 3, half-maximal inhibitory concentration: 10000 nM
Compound 3: middle estimate off by 2.0-fold (0.30 log units), on the high side, and the stated range covers the measured number.
By their numbers in this assay, from the lowest: compounds 2 and 3 (each within the scatter of the next); then compound 1.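

In this assay, methoxymethoxy in place of amino on the carbonyl carbon gives no change at the digits printed from compound 2 to compound 3 (within the scatter), so at this position an ester need not carry a higher number than the amide. The comparison between the two esters, methoxymethoxy in compound 3 and benzyloxy in compound 1, gives a 3.0-fold lower number from compound 1 to compound 3 (0.48 log units; beyond the scatter); the earlier step therefore cannot be read as a simple split between esters and the amide, since what the ester carries past its oxygen also counts here. No measurement at hand gives a reason for either result.

Compounds 2 and 3 show that two quite different groups on this carbonyl carbon can share one number, but not whether that number is a floor for this position or simply where these two groups happen to fall. On these data alone, a free carboxylic acid, a methyl ester or an amide bearing a longer chain on its nitrogen would be the next groups to test this, and the shared core and its long unsaturated chain remain unexplored in these compounds.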